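Indolyl for isobutoxyphenyl: cytotoxicity expected to stay low

This account rests on a few compounds, and the source may have more. Where it says the series, first, only, none or still open, it means among the compounds named here.

Measured compounds:
Compound 1 `CCOC(=O)CCCCCOc1cccc(CN(C(=O)c2ccc(-c3cccc4ccccc34)cc2)C(C)C)c1`: > 26000 nM
Compound 2 `CCOC(=O)CCCCCOc1cccc(CN(C(=O)c2ccc(-c3cccc(OCC(C)C)c3)cc2)C(C)C)c1`: > 26000 nM

Compound 1 and compound 2 share a long core and differ only in the aryl group at the far end of the benzamide. Both were tested in an ADME assay on BJ cells (Homo sapiens) for cytotoxicity, read by CellTiter-Glo and resazurin assay, with a stated time of 72 h; on this read-out lower numbers stand for an effect already at smaller amounts and higher numbers for an effect only at larger amounts of compound. For compound 1 the result is only a limit of the assay, > 26000 nM. For compound 2 the result is likewise only a limit, > 26000 nM. Compound 2 therefore stands at the upper edge of what the assay can report, and the step that the two limits leave unreadable from compound 1 to compound 2 cannot be sized. Going by the values given here, the one piece of evidence is the limit of > 26000 nM in this assay, at which 2 of the 2 values shown sit.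

Compound 3 `CCOC(=O)CCCCCOc1cccc(CN(C(=O)c2ccc(-c3ccc4cc[nH]c4c3)cc2)C(C)C)c1` carries the change (1H-indol-6-yl in place of 3-(isobutoxy)phenyl on an aromatic carbon). Among the compounds with values here, no measured step can be read, so there is nothing that points toward a change beyond the scatter in either direction. Compound 3 is expected to give 30000 nM, with a range from 12000 nM to 100000 nM, most probably again reported only as a limit. The expected step is a step that the limit leaves unreadable from compound 2 to compound 3.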

Compound 3, half-maximal effective concentration: > 26000 nM
Compound 3: only a limit was reported (the forecaster's own chance of this, stated with the estimate: 80%); the middle value is on the limit's open side.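

Compound 3 gives only a limit of the assay, > 26000 nM. No step among compound 1, compound 2 and compound 3 can be read from these results: the limit of > 26000 nM in this assay, at which 3 of the 3 values shown sit.

The compounds shown leave open where the true cytotoxicity of each lies, and whether any aryl group at the far end of the benzamide would give a measurable value.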